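Cytotoxicity notes: fluoro, methylsulfonyl and trifluoromethyl analogues

The source may hold more compounds than are shown below. What is called first, only, known or untested is meant among the compounds shown, and "the series" means these compounds.

Measured so far:
compound 1 `C/C(=C\c1cc(-c2ccc(F)cc2)cs1)C(N)=O` — > 50000 nM
compound 2 `C/C(=C\c1cc(-c2ccc(S(C)(=O)=O)cc2)cs1)C(N)=O` — > 50000 nM

Both values in an ADME assay on NIH3T3 cells (Mus musculus) for cytotoxicity, read by CCK-8 assay, with a stated time of 24 h (on this read-out lower numbers stand for stronger inhibition and higher numbers for weaker inhibition), are limits of the assay and not numbers. Compound 1 reaches only the limit > 50000 nM in this assay. Compound 2 likewise reaches only the limit > 50000 nM in this assay. The step that the two limits leave unreadable from compound 1 to compound 2 is therefore unreadable; both compounds sit at the limit of > 50000 nM in this assay, at which 2 of the 2 values shown sit. Compound 2 thus stands at the top of the measured range, with nothing to separate it from compound 1.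

Compound 3 `C/C(=C\c1cc(-c2ccc(C(F)(F)F)cc2)cs1)C(N)=O` differs from compound 2 by trifluoromethyl in place of methylsulfonyl on an aromatic carbon. Within the data shown here, the only measured step, which also exchanges the group on an aromatic carbon, bears on this change, but its size cannot be read from two limits, so no direction for the new change follows from the measurements. The expected step is a step that the limit leaves unreadable from compound 2 to compound 3, which amounts to no change beyond the scatter. For compound 3 the estimate in this assay is 60000 nM, with a range from 25000 nM to 150000 nM, and the expectation is that again only a limit will be reported.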

Compound 3, half-maximal inhibitory concentration: > 50000 nM
Compound 3 was reported as a limit (the forecaster's own chance of this, stated with the estimate: 85%); the middle value does not contradict the limit.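

In this assay compound 3 gives > 50000 nM, which is a limit of the assay and not a number. Among these compounds, no step among compound 1, compound 2 and compound 3 can be read, as all three sit at one limit: the limit of > 50000 nM in this assay, at which 3 of the 3 values shown sit. The compounds shown leave open whether fluoro, methylsulfonyl and trifluoromethyl differ at all in cytotoxicity beyond that limit.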